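A Ring-Amine Substituent Swap and Its Expected Effect

The compounds below may be only part of what the source reports. "The series", "measured", "known", "first", "only" and "open" are said of these compounds alone.

Measured compounds:
compound 1 `Nc1ccccc1NC(=O)c1ccc(CSC(=S)N2CCN(C3CCCCC3)CC2)cc1`: 76.1%
compound 2 `Nc1ccccc1NC(=O)c1ccc(CSC(=S)N2CCc3cc(Cl)ccc32)cc1`: 65.1%
compound 3 `CN(C(=S)SCc1ccc(C(=O)Nc2ccccc2N)cc1)c1cccnc1`: 70.5%

In a functional assay on HeLa cells (Homo sapiens) for antiproliferative activity, read by CCK-8 assay, with a stated time of 72 h, tested at 8 uM (a higher number here means a stronger effect of the compound at the concentration tested, a lower number a weaker effect), compound 1 gives 76.1%, the highest of the three numbers; compound 3 sits within the scatter of it, while compound 2 lies beyond the scatter below it. The new compound 4 `Nc1ccccc1NC(=O)c1ccc(CSC(=S)N2CCN(Cc3cccnc3)CC2)cc1` differs from compound 1 at one place: (pyridin-3-yl)methyl in place of cyclohexyl on an amine nitrogen in a ring. For the measured compounds named here, no measured step touches that amine nitrogen in a ring. Going by the values given here, the only recorded step, a number 5.4 percentage points higher from compound 2 to compound 3 (within the scatter), concerns the group on the thiocarbonyl carbon and stays within the scatter, and all three measured values cluster closely. A step of no size beyond the scatter is therefore expected in this assay. Compound 4 is expected to give 70%, in the range 55% to 83%. This estimate means a step of a number 6.1 percentage points lower from compound 1 to compound 4 (within the scatter), expected to remain within the scatter.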

Compound 4, a percentage reported as inhibition, at one concentration (the size of the read-out at that concentration, not a potency): 78%
Estimate against measurement, compound 4: 8 percentage points below, and the stated range covers the measured number.
By their numbers in this assay, from the lowest: compounds 2, 3, 1 and 4 (each within the scatter of the next, the first and the last beyond it).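

In this assay the swap on the ring amine nitrogen gives a number 1.9 percentage points higher from compound 1 to compound 4 (within the scatter) as its result, the first step shown at this nitrogen. Cyclohexyl and (pyridin-3-yl)methyl therefore cannot be told apart here, even though the entering group brings an aromatic ring and a hydrogen-bond acceptor. Nothing available explains this likeness. Going by these compounds, whether a plain benzyl group, without the ring nitrogen, would read the same remains open. So does the outcome for a small methyl group, or for a chain ending in a carboxylic acid, on this nitrogen.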